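Swapping fluoro for chloro at an assay limit

The compounds below may be only part of what the source reports. "The series", "measured", "known", "first", "only" and "open" are said of these compounds alone.

Compound 1 `C=C[C@@](C)(/C=C/c1ccc(OCc2ccccc2)cc1)CCC=C(C)C`: > 52000 nM
Compound 2 `C=C[C@@](C)(/C=C/c1ccc(Nc2ccccc2)cc1)CCC=C(C)C`: > 52000 nM
Compound 3 `C=C[C@@](C)(/C=C/c1ccc(Nc2ccc(Cl)c(F)c2)cc1)CCC=C(C)C`: > 52000 nM

All three entries come from a functional assay on HepG2 cells (Homo sapiens) for cytotoxicity, with a stated time of 72 h (a higher number here means that more compound is needed for the effect, a lower number that less compound is needed), and each is a limit of the assay, not a number. On the numbers available, compound 3 stands with the other two compounds at the limit of > 52000 nM in this assay, at which 3 of the 3 values shown sit.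

Compound 4 `C=C[C@@](C)(/C=C/c1ccc(Nc2ccc(Cl)c(Cl)c2)cc1)CCC=C(C)C` differs from compound 3 at a single place: chloro in place of fluoro on an aromatic carbon. This is chloro in place of fluoro on an aromatic carbon, ortho to a chloro group and meta to a large group.

The closest measured change is a step that the two limits leave unreadable from compound 2 to compound 3, where 4-chloro-3-fluorophenyl replaced phenyl on a nitrogen on an aromatic ring. Two further changes also bear on the question: a step that the two limits leave unreadable from compound 1 to compound 2 and a step that the two limits leave unreadable from compound 1 to compound 3. None of these has a size that can be carried over to the new change, and none indicates a direction. Only the shared limit remains as a guide, so no step beyond the scatter is expected, and compound 4 will most likely be reported as a limit again.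

The expected outcome is a step that the limit leaves unreadable from compound 3 to compound 4. In this assay the estimated value for compound 4 is 55000 nM, with an expected range from 28000 nM to 110000 nM.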

Compound 4, half-maximal effective concentration: > 52000 nM
Compound 4 gave a limit, no number; the forecaster's own chance of this, stated with the estimate: 85%; the middle value lies beyond the limit too.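

In this assay compound 4 gives > 52000 nM, a limit and not a number. Its steps from compound 1, compound 2 and compound 3 therefore cannot be read, and all four compounds share one result: the limit of > 52000 nM in this assay, at which 4 of the 4 values shown sit.

The compounds shown leave open whether chloro and fluoro differ at all in this assay, and what value any of these compounds would reach there.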